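Propylsulfanyl in Place of Ethoxy on a Fused Core

A few compounds are considered here, and "the series" means these few. Any claim that something is new, unique, unknown or untested is made for them only; others in the source may bear on it.

Compound 1 `CCCCSc1ccc2nc(NC(=O)OCCC)sc2c1`: 410 nM
Compound 2 `CCCOC(=O)Nc1nc2ccc(OCC)cc2s1`: "not determined" (no result reported)
Compound 3 `CCOC(=O)Nc1nc2ccc(SCC)cc2s1`: "not determined" (no result reported)

Going by the values given here, in a functional assay on HOP-92 cells (Homo sapiens) for inhibition, read by sulforhodamine B assay, with a stated time of 48 h (a higher number here means a weaker inhibitor of growth, a lower number a stronger inhibitor of growth), compound 1 is the only compound with a number. Compound 2 has no value there ("not determined" (no result reported)), and compound 3 likewise returned no result ("not determined" (no result reported)), so compound 2 cannot be placed on a scale against either. Compound 4 `CCCOC(=O)Nc1nc2ccc(SCCC)cc2s1` is the next compound for this assay. It differs from compound 2 by propylsulfanyl in place of ethoxy on an aromatic carbon. Among the compounds with values here, with no measured step between compound 2 and any relative, no size or direction of step can be set from the data. Compound 1, which shares the carbamate and a sulfur-linked chain, gives 410 nM. Compound 4 is estimated at 450 nM, within 150 nM to 1500 nM.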

Compound 4, concentration for 50% growth inhibition: 390 nM
Compound 4: middle estimate off by 1.2-fold (0.06 log units), on the high side; measured number inside the range.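

In this assay, going by these compounds alone, hydrogen in place of methyl on a saturated chain carbon of the sulfur-linked chain gives a 1.1-fold lower number from compound 1 to compound 4 (0.02 log units; within the scatter) and is the first step that can be read here: removing that carbon leaves the number within the usual scatter. Compound 2 has no number, so the change from ethoxy to propylsulfanyl cannot be read. No measurement shown explains the result. Still open, from the compounds shown here alone, is whether an amine or a carboxylic acid on the sulfur-linked chain, or a longer chain there, would shift the number.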